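A few compounds are considered here, and "the series" means these few. Any claim that something is new, unique, unknown or untested is made for them only; others in the source may bear on it.

Of the compounds shown here, three sharing one core have been measured in a functional assay on the whole organism with Rattus norvegicus as the target, at a dose of 20 mg/kg by the intraperitoneal route; a lower number here means less inhibition, a higher number more inhibition at the dose given (going by the name of the read-out). Compound 1 `Nc1nc(N)nc(-c2ccccc2Br)n1` gives 26% in this assay. Compound 2 `Nc1nc(N)nc(-c2cc(F)ccc2Cl)n1` gives 78%. Compound 3 `COc1ccccc1-c1nc(N)nc(N)n1` gives 1%, the lowest of the three numbers; its nearest neighbour is compound 1, and the gap to compound 2 is wider still. For the measured compounds named here, the one measured step that touches compound 3 is a number 25 percentage points lower from compound 1 to compound 3 (beyond the scatter), methoxy in place of bromo on an aromatic carbon.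

Compound 4 `Nc1nc(N)nc(-c2ccccc2Cl)n1` has not yet been measured in this assay. It differs from compound 3 by chloro in place of methoxy on an aromatic carbon. The step that bears on this change is a number 25 percentage points lower from compound 1 to compound 3 (beyond the scatter), which exchanged a halogen for methoxy at the same carbon; chloro in place of methoxy runs in the opposite direction, so a rise of comparable size is expected. Compound 2, which carries chloro together with a fluoro, shows 78%, but no single change links it to compound 4, so only its value can be noted. The expected step is therefore a number 29 percentage points higher from compound 3 to compound 4 (beyond the scatter) in this assay. Compound 4 is estimated at 30%, with a likely range from 5% to 60%.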

Compound 4, a percentage reported as inhibition, in the whole organism at one dose (the size of the read-out at that dose, not a potency): 36%
Compound 4: the middle estimate sits 6 percentage points below what was measured; low and high end bracket the measured number.
By their numbers in this assay, from the lowest: compound 3; then compounds 1 and 4 (each within the scatter of the next); then compound 2.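

Chloro in place of methoxy gives a number 35 percentage points higher from compound 3 to compound 4 (beyond the scatter) and chloro in place of bromo gives a number 10 percentage points higher from compound 1 to compound 4 (within the scatter) in this assay so on this aromatic carbon the two halogens cannot be told apart, while methoxy stands apart from both. The other new step, a number 42 percentage points lower from compound 2 to compound 4 (beyond the scatter) for hydrogen in place of fluoro, shows that a change elsewhere on the ring can move the number beyond the scatter even with chloro held constant. No measurement is at hand that would explain any of these steps.

As far as these compounds go, whether an amine, a hydroxyl or a methyl on this carbon would stay with the halogens or with methoxy remains open. From the compounds shown here alone, it is also open whether fluoro would have a comparable effect alongside bromo or methoxy.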